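Notes on the series: compound 2 to compound 3

This account rests on a few compounds, and the source may have more. Where it says the series, first, only, none or still open, it means among the compounds named here.

Measured in a functional assay on A549 cells (Homo sapiens) for cytotoxicity, read by MTT assay, with a stated time of 72 h; a lower number here means a stronger inhibitor, a higher number a weaker inhibitor:
- compound 1 `COc1ccc(/C=C2\CCC/C(=C\c3ccccc3Br)C2=O)cc1OC`: > 20000 nM, a limit
- compound 2 `COc1ccc(/C=C2\CCC/C(=C\c3ccc(O)cc3)C2=O)cc1OC`: > 20000 nM, a limit

Compound 2 has no number, only a limit, and the one other result is a limit too: the limit of > 20000 nM in this assay, at which 2 of the 2 values shown sit.

Compound 3 `COc1ccc(/C=C2\CCC/C(=C\c3ccc(Cl)c(Cl)c3)C2=O)cc1OC` has 3,4-dichlorophenyl in place of 4-hydroxyphenyl on a double-bonded chain carbon bound to a double-bonded ring carbon.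

Within the data shown here, the only measured step is a step that the two limits leave unreadable from compound 1 to compound 2, so no size or direction can be carried over from it. With only limits to go on, little change is expected in this assay, and compound 3 is expected to stay close to that limit. The expected step is an at least 1.3-fold lower number from compound 2 to compound 3 (0.12 log units; that floor lies within the scatter). For compound 3 the estimated value is 15000 nM, with an expected range of 5000 nM to 30000 nM.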

Compound 3, half-maximal inhibitory concentration: 6900 nM
Estimate against measurement, compound 3: 2.2-fold (0.34 log units) above; low and high end bracket the measured number.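

Compound 3 is the first compound shown with a readable number in this assay, so the group on the double-bonded chain carbon bound to a double-bonded ring carbon can move the read-out: 3,4-dichlorophenyl in place of 4-hydroxyphenyl gives an at least 2.8-fold lower number from compound 2 to compound 3 (0.46 log units; beyond the scatter). The change from 2-bromophenyl to 3,4-dichlorophenyl gives an at least 2.8-fold lower number from compound 1 to compound 3 (0.46 log units; beyond the scatter), so both steps give only a minimum size, with the same direction. The step between compound 1 and compound 2 cannot be read, and the limit remains the most common result: the limit of > 20000 nM in this assay, at which 2 of the 3 values shown sit.

On these data alone, it remains open whether 4-chlorophenyl or 3-chlorophenyl alone would give a number like that of compound 3, or whether both chlorines are needed. Also open, as far as these compounds go, is how an amine such as 4-dimethylaminophenyl would read at this place.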